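The source may report more compounds than this note shows. Statements on the series, on what has been measured and on what is new or still open speak of the compounds shown alone.

Compounds measured so far:
- Compound 1 `CCCCCCCCCCCCCCCC(=O)OC1=C(CC=C(C)C)C(=O)c2ccccc2C1=O`: 29000 nM
- Compound 2 `CCCCCCCCCCCCCCCCCC(=O)OC1=C(CC=C(C)C)C(=O)c2ccccc2C1=O`: > 100000 nM, a limit of the assay and not a number

These values come from a functional assay on LoVo cells (Homo sapiens) for inhibition, read by MTT assay; on this read-out lower numbers stand for stronger inhibition and higher numbers for weaker inhibition. Compound 2 gives no exact number and stands at the limit: the limit of > 100000 nM in this assay, at which 1 of the 2 values shown sits.

Compound 3 `CCCCCCCC/C=C\CCCCCCCC(=O)OC1=C(CC=C(C)C)C(=O)c2ccccc2C1=O` carries dec-1-en-1-yl in place of decyl on a saturated chain carbon, seven bonds along the chain from a carbonyl carbon, with dec-1-en-1-yl in place of decyl on a saturated chain carbon, seven bonds along the chain from a carbonyl carbon. Going by the values given here, the only measured step in this chain is an at least 3.4-fold higher number from compound 1 to compound 2 (0.53 log units; beyond the scatter). Among the compounds with values here, no measured step tests a double bond, so this guide is loose. The expected change is an at least 1.8-fold lower number from compound 2 to compound 3 (0.25 log units; that floor lies within the scatter), modest and towards stronger inhibition. For compound 3, the estimated value is 55000 nM, with an expected range of 18000 nM to 100000 nM.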

Compound 3, half-maximal inhibitory concentration: 57000 nM
Compound 3: the middle estimate sits 1.0-fold (0.02 log units) below what was measured; measured number inside the range.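

Placing dec-1-en-1-yl in place of decyl, seven bonds along the chain from a carbonyl carbon, tests a double bond in this chain for the first time, and in this assay it gives an at least 1.7-fold lower number from compound 2 to compound 3 (0.24 log units; that floor lies within the scatter). Compound 2 has a limit and not a number: the limit of > 100000 nM in this assay, at which 1 of the 3 values shown sits.

The other step, a 2.0-fold higher number from compound 1 to compound 3 (0.29 log units; within the scatter), means that the octyl and dec-1-en-1-yl chains cannot be told apart here.

The compounds shown leave open how a much shorter chain, or a chain ending in an amine or a carboxylic acid, would read in this assay.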